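The source may hold more compounds than are shown below. What is called first, only, known or untested is meant among the compounds shown, and "the series" means these compounds.

Compound 3 `Cc1nc(NCc2ccsc2)nc(N[C@@H]2C[C@H](CO)[C@@H](O)[C@H]2O)c1-c1nc2ccccc2s1` carries a (thiophen-3-yl)methyl group on an amino nitrogen of the shared core. In an ADME assay on cells (Homo sapiens) for cytotoxicity, read by polymerase chain reaction, with a stated time of 3 days (on this read-out lower numbers stand for higher toxicity in this test and higher numbers for lower toxicity in this test), compound 3 gives 6000 nM. Of the two numbers shown, this is the lowest; the nearest is compound 1 `CCNc1nc(C)c(-c2nc3ccccc3s2)c(N[C@@H]2C[C@H](CO)[C@@H](O)[C@H]2O)n1`, which in this assay gives 12000 nM, and the gap a 2.0-fold lower number from compound 1 to compound 3 (0.30 log units; within the scatter) is within the scatter. Compound 2 `CCCNc1nc(C)c(-c2nc3ccccc3s2)c(N[C@@H]2C[C@H](CO)[C@@H](O)[C@H]2O)n1` gives only a limit in this assay, > 25000 nM. That limit is recorded as the limit of > 25000 nM in this assay, at which 1 of the 3 values shown sits.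

Compound 4 `Cc1nc(NCc2ccccn2)nc(N[C@@H]2C[C@H](CO)[C@@H](O)[C@H]2O)c1-c1nc2ccccc2s1` has not yet been measured. It differs from compound 3 in one place: pyridin-2-yl in place of thiophen-3-yl on a saturated chain carbon bound to a nitrogen on an aromatic ring. Going by the values given here, the measured steps at this position are a 2.0-fold lower number from compound 1 to compound 3 (0.30 log units; within the scatter) and an at least 4.1-fold lower number from compound 2 to compound 3 (0.61 log units; beyond the scatter); both replace a short alkyl group with the thiophen-3-yl ring, and neither exchanges one aromatic ring for another, so no measured step speaks directly to the change at hand. What they show is that the two aromatic-bearing and alkyl-bearing compounds sit within a narrow band, with only the ethyl-bearing compound 2 set apart by a limit.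

For compound 4 the estimate in this assay is therefore 8000 nM, with a range from 3000 nM to 25000 nM. The step this estimate implies, a 1.3-fold higher number from compound 3 to compound 4 (0.12 log units; within the scatter), is expected to stay within the scatter.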

Compound 4, half-maximal cytotoxic concentration: 13000 nM
Compound 4: middle estimate off by 1.6-fold (0.21 log units), on the low side; the measured number falls inside the stated range.
By their numbers in this assay, from the lowest: compounds 3, 1 and 4 (each within the scatter of the next, the first and the last beyond it). At a limit, above all of these: compound 2.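

In this assay, going by these compounds alone, this is the first exchange of one aromatic ring for another on this saturated chain carbon, and the choice of ring counts, giving a 2.2-fold higher number from compound 3 to compound 4 (0.34 log units; beyond the scatter). A ring here does not by itself set the number apart from a short alkyl group, as the pyridin-2-yl compound shows a 1.1-fold higher number from compound 1 to compound 4 (0.03 log units; within the scatter), so compound 4 cannot be told from compound 1, while compound 3 is still within the scatter of compound 1. The comparison with the remaining alkyl compound gives an at least 1.9-fold lower number from compound 2 to compound 4 (0.28 log units; that floor lies within the scatter), which does not separate the two, and the value of compound 2 is only a limit of the assay: the limit of > 25000 nM in this assay, at which 1 of the 4 values shown sits.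

The change from thiophen-3-yl to pyridin-2-yl alters ring size and swaps a sulfur for a nitrogen in a single step, so the compounds shown leave open which of these goes with the higher number. A phenyl group on the same carbon would separate ring size from the hetero atom, and a pyridin-3-yl or pyridin-4-yl group would test whether the place of the ring nitrogen matters.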